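A few compounds are considered here, and "the series" means these few. Any claim that something is new, unique, unknown or untested is made for them only; others in the source may bear on it.

Measured so far in an assay on HEK293 cells for inhibition of Voltage-dependent T-type calcium channel subunit alpha-1G (Homo sapiens), read by patch clamp, tested at 10 uM; a lower number here means less inhibition, a higher number more inhibition at the concentration tested (going by the name of the read-out):
compound 1, `O[C@H](COc1ccc(C(F)(F)F)cc1)CN1CCN(c2ccccc2F)CC1`, gives 48.9%
compound 2, `O[C@H](COc1ccc(Cl)cc1)CN1CCN(c2ccccc2F)CC1`, gives 35.9%
compound 3, `O[C@@H](COc1ccc(C(F)(F)F)cc1)CN1CCN(c2ccc(F)cc2)CC1`, gives 53.7%

Compound 1 and compound 3 share the same atoms joined differently; the difference between the two cores is not broken down here. Their two values lie within the usual scatter of each other, so nothing separates them. Compound 2 stands apart from compound 3 by a gap that goes beyond the scatter.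

Going by the values given here, the one counted step among the measured compounds runs from compound 1 to compound 2: chloro in place of trifluoromethyl on an aromatic carbon. This gave a number 13 percentage points lower from compound 1 to compound 2 (beyond the scatter).

Compound 4, `O[C@@H](COc1ccc(Cl)cc1)CN1CCN(c2ccc(F)cc2)CC1`, has not yet been measured. It arises from compound 3 by the same change, (chloro in place of trifluoromethyl on an aromatic carbon), at a place described in the same words. The step is expected to be a number 12.7 percentage points lower from compound 3 to compound 4 (beyond the scatter), a modest fall, because the same change gave a number 13 percentage points lower from compound 1 to compound 2 (beyond the scatter). Compound 4 is therefore estimated at about 41%. The range for compound 4 is estimated to run from 28% to 54%.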

Compound 4, a percentage reported as inhibition, at one concentration (the size of the read-out at that concentration, not a potency): 39.7%
Compound 4: the middle estimate sits 1.3 percentage points above what was measured, and the stated range covers the measured number.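

Putting chloro in place of trifluoromethyl on the aromatic ring gave a number 14 percentage points lower from compound 3 to compound 4 (beyond the scatter). In this assay, the change therefore carried over from one core to the other, in direction and in size, with no difference between the two steps: the same change on two cores in this assay, a number 13 percentage points lower (beyond the scatter) from compound 1 to compound 2 and a number 14 percentage points lower (beyond the scatter) from compound 3 to compound 4, 1 percentage points apart, within the scatter of two such steps

These two pairs do not show that the change would act the same way on any core beyond these two, and they do not explain why the number falls; each reading also comes from one concentration, so it is not a measure of potency.

As far as these compounds go, only trifluoromethyl and chloro appear at this place on the ring, so it remains open how a nitrile, a methoxy group or an amine would fare there. Also open, from the compounds shown here alone, is what a longer chain in place of the one linking the two ends of these molecules would do to the reading in this assay.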